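Aryl Group Exchange on the Shared Core

The source may report more compounds than this note shows. Statements on the series, on what has been measured and on what is new or still open speak of the compounds shown alone.

Compound 1 `CC(C)n1ncc2c(C(=O)NCc3cn(-c4cccc(Br)c4)nn3)cccc21` gives > 40000 nM in a functional assay on HepG2 cells (Homo sapiens) for inhibition, read by MTT assay, with a stated time of 72 h (a lower number here means a stronger inhibitor, a higher number a weaker inhibitor), a limit rather than a number.
Compound 2 `Cc1cccc(-n2cc(CNC(=O)c3cccc4c3cnn4C(C)C)nn2)c1` gives > 40000 nM in this assay, likewise only a limit.

Compound 2 thus stands at the limit, with no number to place it. The step that the two limits leave unreadable from compound 1 to compound 2 cannot be read because both values sit at the limit of > 40000 nM in this assay, at which 2 of the 2 values shown sit. Compound 3 `CCc1ccc(-n2cc(CNC(=O)c3cccc4c3cnn4C(C)C)nn2)cc1` differs from compound 2 by 4-ethylphenyl in place of 3-methylphenyl on an aromatic nitrogen. Within the data shown here, the only measured step alters the same aryl group and is unreadable, so no size or direction beyond the scatter can be drawn from it. Compound 3 is therefore expected to remain at the limit, estimated at 60000 nM with a range of 20000 nM to 200000 nM. The expected step is a step that the limit leaves unreadable from compound 2 to compound 3.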

Compound 3, half-maximal inhibitory concentration: > 40000 nM
Compound 3: only a limit was reported; the forecaster's own chance of this, stated with the estimate: 85%; the middle value does not contradict the limit.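

Neither step to compound 3, from compound 1 or from compound 2, can be read, because all three values are limits: the limit of > 40000 nM in this assay, at which 3 of the 3 values shown sit.

The compounds shown leave open whether any aryl group on the shared core gives a readable value in this assay.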